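Side-chain trimming on the shared core: compound 3 to compound 4

The compounds below may be only part of what the source reports. "The series", "measured", "known", "first", "only" and "open" are said of these compounds alone.

Measured so far in an assay on isolated protein for inhibition of protein kinase C epsilon type (Homo sapiens), read by coupled enzyme assay; a lower number here means a stronger inhibitor, a higher number a weaker inhibitor:
compound 1 `CCC(O)Cc1cc(-c2ccnc3[nH]nc(C(F)(F)F)c23)cc(C2(C#N)CC2)c1`, 49 nM
compound 2 `COCC(O)Cc1cc(-c2ccnc3[nH]nc(C(F)(F)F)c23)cc(C2(C#N)CC2)c1`, 77 nM
compound 3 `CC(=O)OCCc1cc(-c2ccnc3[nH]nc(C(F)(F)F)c23)cc(C2(C#N)CC2)c1`, 119 nM

Compound 3 carries the highest of the three numbers in this assay; its nearest neighbour is compound 2, a 1.5-fold higher number from compound 2 to compound 3 (0.19 log units; within the scatter), and its furthest is compound 1, a 2.4-fold higher number from compound 1 to compound 3 (0.39 log units; beyond the scatter), the latter a modest difference. Compound 4 `CCc1cc(-c2ccnc3[nH]nc(C(F)(F)F)c23)cc(C2(C#N)CC2)c1` is not yet measured; it differs from compound 3 by hydrogen in place of acetoxy on a saturated chain carbon, two bonds along the chain from an aromatic carbon. Among the measured compounds shown here, no measured step removes the oxygen-bearing part of this side chain outright, so none bears on the change directly. The steps that vary the same chain, a 2.4-fold higher number from compound 1 to compound 3 (0.39 log units; beyond the scatter) and a 1.5-fold higher number from compound 2 to compound 3 (0.19 log units; within the scatter), stay small, which suggests this position tolerates change without large swings in this assay. For compound 4 a step no larger than those, in either direction, is expected, a 1.3-fold higher number from compound 3 to compound 4 (0.10 log units; within the scatter). The estimate for compound 4 in this assay is 150 nM, with a range of 60 nM to 400 nM.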

Compound 4, inhibition constant: 78 nM
Beside the measured number, compound 4's estimate is 1.9-fold (0.28 log units) above it, and the stated range covers the measured number.
By their numbers in this assay, from the lowest: compounds 1, 2, 4 and 3 (each within the scatter of the next, the first and the last beyond it).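

In this assay, taking the oxygen-bearing part off the side chain outright gives a 1.5-fold lower number from compound 3 to compound 4 (0.18 log units; within the scatter), so hydrogen in place of acetoxy on this saturated chain carbon leaves the reading within the scatter. The plain ethyl group also compares closely with the hydroxylated chains, with a 1.0-fold higher number from compound 2 to compound 4 (0.01 log units; within the scatter) and a 1.6-fold higher number from compound 1 to compound 4 (0.20 log units; within the scatter), so among these compounds neither the hydroxyl nor the acetoxy group is needed for a value in this range, and compound 4 lies within the scatter of compound 1, compound 2 and compound 3. No measurement shown accounts for this tolerance.

On these data alone, whether an amine, a carboxylic acid or a longer chain on this saturated chain carbon would stay in the same narrow band remains open. Also open, as far as these compounds go, is whether the shared core tolerates changes elsewhere as it does here.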